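A few compounds are considered here, and "the series" means these few. Any claim that something is new, unique, unknown or untested is made for them only; others in the source may bear on it.

In a functional assay on Hep 3B2 cells (Homo sapiens) for inhibition, read by MTT assay, with a stated time of 72 h (on this read-out lower numbers stand for stronger inhibition and higher numbers for weaker inhibition), compound 1 (`Nc1nc2cc(-c3nn(CCCCCCCCCC(=O)NO)c4ncnc(N)c34)ccc2o1`) gives 28800 nM, compound 2 (`Nc1nc2cc(-c3nn(CCCCC(=O)NO)c4ncnc(N)c34)ccc2o1`) gives 33700 nM and compound 3 (`Nc1nc2cc(-c3nn(CCCCCC(=O)NO)c4ncnc(N)c34)ccc2o1`) gives 34200 nM, so compound 3 stands level with the other two, all within the scatter. Compound 4 (`Nc1nc2cc(-c3nn(CCCCCCC(=O)NO)c4ncnc(N)c34)ccc2o1`) differs from compound 3 by (hydroxycarbamoyl)methyl in place of hydroxycarbamoyl on a saturated chain carbon, five bonds along the chain from an aromatic nitrogen. The same exchange, made four bonds along the chain from an aromatic nitrogen, is a 1.0-fold higher number from compound 2 to compound 3 (0.01 log units; within the scatter). The wider chain changes are no larger: a 1.2-fold higher number from compound 1 to compound 3 (0.07 log units; within the scatter) and a 1.2-fold higher number from compound 1 to compound 2 (0.07 log units; within the scatter), both within the scatter. No step beyond the scatter is therefore expected in this assay. The expected change is a 1.1-fold lower number from compound 3 to compound 4 (0.04 log units; within the scatter), within the scatter. For compound 4 the estimated value is 31000 nM, with an expected range of 17000 nM to 52000 nM.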

Compound 4, half-maximal inhibitory concentration: 14000 nM
Compound 4: the middle estimate sits 2.2-fold (0.35 log units) above what was measured, and the stated range ends above it.
By their numbers in this assay, from the lowest: compound 4; then compounds 1, 2 and 3 (each within the scatter of the next).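

In this assay, among these compounds, the exchange of hydroxycarbamoyl for (hydroxycarbamoyl)methyl, five bonds along the chain from an aromatic nitrogen, gives the first step beyond the scatter: a 2.4-fold lower number from compound 3 to compound 4 (0.39 log units; beyond the scatter). Among the compounds shown here, the same exchange four bonds along gave no such step. The lower number also holds against a shorter chain, a 2.4-fold lower number from compound 2 to compound 4 (0.38 log units; beyond the scatter), and a longer one, a 2.1-fold lower number from compound 1 to compound 4 (0.31 log units; beyond the scatter), so chain length acts here as a narrow optimum, not a steady trend, with compound 1 level with compounds 2 and 3.

Going by these compounds, whether a carboxylic acid or an amine at the chain end would keep the lower number of compound 4 stays open. Nothing at hand explains the step.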